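The source may report more compounds than this note shows. Statements on the series, on what has been measured and on what is new or still open speak of the compounds shown alone.

Measured so far in a physicochemical assay for lipophilicity; on this read-out higher numbers stand for higher lipophilicity and lower numbers for lower lipophilicity:
Compound 1, `Ic1ccccc1C1=NC(c2ccccc2)CO1`: compound 1 gives 3.86.
Compound 2, `CCSc1ccccc1C1=NC(c2ccccc2)CO1`: compound 2 gives 4.04.
Compound 3, `CCOc1ccccc1C1=NC(c2ccccc2)CO1`: compound 3 gives 4.22.

Compound 3 stands highest of the three numbers in this assay. Its nearest neighbour is compound 2, and that gap, a number 0.18 log units higher from compound 2 to compound 3 (within the scatter), stays within the scatter, so no order between the two can be claimed. Its furthest is compound 1, and there a number 0.36 log units higher from compound 1 to compound 3 (beyond the scatter) is a modest step beyond the scatter.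

Compound 4, `FC(F)(F)c1ccccc1C1=NC(c2ccccc2)CO1`, is not yet measured. It differs from compound 3 in one place: trifluoromethyl in place of ethoxy on an aromatic carbon

Among the compounds with values here, the steps that bear on this change are those at the same aromatic carbon, a number 0.36 log units higher from compound 1 to compound 3 (beyond the scatter) and a number 0.18 log units higher from compound 2 to compound 3 (within the scatter), and both were small. Within the data shown here, no measured step involves trifluoromethyl, so the direction for compound 4 rests on weak ground. He therefore expects a step from compound 3 to compound 4 of about a number 0.12 log units lower from compound 3 to compound 4 (within the scatter) in this assay, within the scatter. His estimate for compound 4 is 4.1, with a range from 3.7 to 4.5.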

Compound 4, partition coefficient: 3.71
Beside the measured number, compound 4's estimate is 0.39 log units above it; the range from low to high includes it.
By their numbers in this assay, from the lowest: compounds 4, 1, 2 and 3 (each within the scatter of the next, the first and the last beyond it).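

Within the data shown here, at this position, on an aromatic carbon ortho to a large group, trifluoromethyl gives the first downward step in this assay, and a number 0.51 log units lower from compound 3 to compound 4 (beyond the scatter) is also the largest step yet seen there. Among these compounds, it also separates trifluoromethyl from ethylsulfanyl, with a number 0.33 log units lower from compound 2 to compound 4 (beyond the scatter), but not from iodo, with a number 0.15 log units lower from compound 1 to compound 4 (within the scatter), so trifluoromethyl and iodo cannot be put in order, and the groups at this position now cover a wider span of numbers than the earlier compounds showed. Nothing available here explains these steps.

On these data alone, how an amine, a carboxylic acid or a longer chain at this position would stand in this assay remains open. As far as these compounds go, it is also open whether trifluoromethyl in place of ethoxy would give a similar step on another aromatic carbon or on a different core.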